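Pyrazoline series: hydroxyphenyl versus chlorophenyl on the saturated carbon

The compounds below may be only part of what the source reports. "The series", "measured", "known", "first", "only" and "open" are said of these compounds alone.

Measured compounds:
compound 1 `CC(C)c1ccc(N2N=C(C(C)(C)C)CC2c2ccc(O)cc2)cc1`: 54.9%
compound 2 `Cc1cccc(N2N=C(C(C)(C)C)CC2c2ccc(O)cc2)c1`: 91.7%
compound 3 `CC(C)(C)C1=NN(c2ccc(Cl)cc2)C(c2ccc(Cl)cc2)C1`: 11.8%

In an assay on isolated protein for inhibition of protein kinase C zeta type (Homo sapiens), with a stated time of 4 min, tested at 62.5 uM (on this read-out higher numbers stand for more inhibition at the one concentration tested (going by the name of the read-out) and lower numbers for less inhibition), compound 3 gives 11.8%, the lowest of the three numbers, beyond the scatter under compound 1 and further still under compound 2. Both of the higher compounds carry a hydroxyphenyl group on the saturated carbon of the shared core, whereas compound 3 carries a chlorophenyl group there.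

Compound 4 `CC(C)(C)C1=NN(c2ccc(Cl)cc2)C(c2cccc(O)c2)C1` is not yet measured. It differs from compound 3 in one place: 3-hydroxyphenyl in place of 4-chlorophenyl on a saturated ring carbon. No step between measured compounds isolates this exchange, so the size is uncertain, but on the numbers shown a rise beyond the scatter is expected, estimated at a number 28.2 percentage points higher from compound 3 to compound 4 (beyond the scatter). For compound 4 the expected value in this assay is 40%, within a range from 15% to 70%.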

Compound 4, a percentage reported as inhibition, at one concentration (the size of the read-out at that concentration, not a potency): 95.6%
The estimate for compound 4 lay 55.6 percentage points below the measured number; the whole stated range lies below it.
By their numbers in this assay, from the lowest: compound 3; then compound 1; then compounds 2 and 4 (each within the scatter of the next).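

Exchanging 4-chlorophenyl for 3-hydroxyphenyl on the saturated ring carbon, with nothing else changed, gives a number 83.8 percentage points higher from compound 3 to compound 4 (beyond the scatter) in this assay. For the compounds shown here, this is the first reading of this position alone, and compound 4 shows that a 4-chlorophenyl group elsewhere on the shared core is compatible with a high number. Nothing at hand gives a reason for this step.

Going by these compounds, it stays open whether the hydroxyl itself or its place on the phenyl ring accounts for the step. A 3-methoxyphenyl or 3-aminophenyl group at this carbon could separate these two readings.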